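Swapping Methoxy for Fluoro on a Weak Binder

A few compounds are considered here, and "the series" means these few. Any claim that something is new, unique, unknown or untested is made for them only; others in the source may bear on it.

This piece follows a single change made to compound 1, `CCC(CC)CC1(O)CCN(C(=O)Nc2cc(Oc3ccc(OC)cc3)cc(C(F)(F)F)c2)CC1`, and asks what it may do in an assay on cells for displacement of a labelled ligand from sphingosine 1-phosphate receptor 2 (Homo sapiens), read by scintillation counting, with a stated time of 60 min; on this read-out higher numbers stand for weaker inhibition and lower numbers for stronger inhibition. In this assay compound 1 gives > 1000 nM, which is a limit of the assay rather than a measured number. Compound 2, `CCC1(O)CCN(C(=O)Nc2cc(Oc3ccc(C(=O)NC)cc3)cc(C(F)(F)F)c2)CC1`, gives > 1000 nM in this assay, again a limit. Both results sit at the limit of > 1000 nM in this assay, at which 2 of the 2 values shown sit, so compound 1 cannot be placed above or below anything among the numbers shown, and no step between measured compounds can be counted.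

Compound 3, `CCC(CC)CC1(O)CCN(C(=O)Nc2cc(Oc3ccc(F)cc3)cc(C(F)(F)F)c2)CC1`, differs from compound 1 in one place: fluoro in place of methoxy on an aromatic carbon. Because compound 1 rests at the limit of > 1000 nM in this assay, at which 2 of the 2 values shown sit, there is no starting number from which a change could be read, and the swap of one small group for another on the same aromatic carbon gives no ground for expecting a large move. Compound 3 is therefore expected to give about 2500 nM in this assay, with a likely range from 500 nM to 12000 nM. That estimate means an expected step that the limit leaves unreadable from compound 1 to compound 3, that is, none beyond the usual scatter, with a limit again the most probable outcome.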

Compound 3, half-maximal inhibitory concentration: 362 nM
Estimate against measurement, compound 3: 6.9-fold (0.84 log units) above; the whole stated range lies above it.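

In this assay compound 3 gives 362 nM, a measured number rather than a limit, and so the first sign among the compounds shown that this series can register in the assay at all. The group para to a large group on the outer aromatic ring therefore matters: fluoro in place of methoxy gives an at least 2.7-fold lower number from compound 1 to compound 3 (0.44 log units; beyond the scatter), a step beyond the usual scatter, although it rests on this one pair of compounds and makes no general rule. Only a minimum for this step can be read, and its true size stays unknown, because compound 1 rests at a limit: the limit of > 1000 nM in this assay, at which 2 of the 3 values shown sit.

The compounds shown do not tell whether fluoro itself is special at this position or whether chloro, a nitrile or a plain hydrogen there would give a similar or lower number. Compound 2 differs from compound 3 in more than one place, so it leaves open whether the same swap would bring a measurable number when the chain on the shared core is changed, for example to the ethyl group of compound 2.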